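The source may report more compounds than this note shows. Statements on the series, on what has been measured and on what is new or still open speak of the compounds shown alone.

Measured so far:
Compound 1 `Cc1ccc(S(=O)(=O)NN2C(=S)S/C(=C\c3ccc(Cl)c(Cl)c3)C2O)cc1`: in a functional assay on ECV-304 cells (Homo sapiens) for cytotoxicity (a lower number here means a stronger inhibitor, a higher number a weaker inhibitor), compound 1 is reported only as a limit, > 50000 nM.
Compound 2 `O=S(=O)(NN1C(=S)S/C(=C\c2ccc(Cl)c(Cl)c2)C1O)c1ccc(F)cc1`: in this assay compound 2 is likewise reported only as a limit, > 50000 nM.

Compound 2 thus has no number of its own; it sits at the limit, as the limit of > 50000 nM in this assay, at which 2 of the 2 values shown sit, shows for both measured compounds. Going by the values given here, the one measured step, a step that the two limits leave unreadable from compound 1 to compound 2, gives no readable size. Compound 3 `O=S(=O)(NN1C(=S)S/C(=C\c2ccc(Cl)c(Cl)c2)C1O)c1ccccc1F` differs from compound 2 by 2-fluorophenyl in place of 4-fluorophenyl on a sulfonyl sulfur. Among the compounds with values here, no measured step bears on this change, so no shift beyond the scatter can be claimed in either direction. Compound 3 is expected to stay near the limit, at an estimated 60000 nM in this assay, ranging from 20000 nM to 200000 nM. The step this estimate means is expected to be a step that the limit leaves unreadable from compound 2 to compound 3.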

Compound 3, half-maximal inhibitory concentration: > 50000 nM
Compound 3 was reported as a limit (the forecaster's own chance of this, stated with the estimate: 80%); the middle value is on the limit's open side.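

Going by these compounds alone, compound 1, compound 2 and compound 3 all sit at one limit, so no step among them can be read: the limit of > 50000 nM in this assay, at which 3 of the 3 values shown sit. From the compounds shown here alone, whether 4-methylphenyl, 4-fluorophenyl and 2-fluorophenyl truly differ in this assay stays open.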